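A few compounds are considered here, and "the series" means these few. Any claim that something is new, unique, unknown or untested is made for them only; others in the source may bear on it.

In a functional assay on HeLa cells (Homo sapiens) for cytotoxicity, read by MTT assay, with a stated time of 2 days, tested at 100 uM (on this read-out lower numbers stand for a stronger effect and higher numbers for a weaker effect at the one concentration tested), three compounds built on one shared core have been measured. Compound 1 `CC(=O)c1cc(-c2ccccc2)cc2cc(-c3ccccc3)[nH]c12` gives 51.4%. Compound 2 `CC(=O)c1cc(-c2ccc(F)cc2)cc2cc(-c3ccccc3)[nH]c12` gives 24.8%, and compound 3 `COc1ccc(-c2cc(C(C)=O)c3[nH]c(-c4ccccc4)cc3c2)cc1` gives 21.1%. Among these three numbers compound 3 stands lowest; its nearest neighbour is compound 2, whose number lies within the usual scatter of it, while compound 1 lies apart, beyond the scatter. The two steps that start from compound 1 were both clear: a number 26.6 percentage points lower from compound 1 to compound 2 (beyond the scatter), and a number 30.3 percentage points lower from compound 1 to compound 3 (beyond the scatter). By contrast a number 3.7 percentage points lower from compound 2 to compound 3 (within the scatter).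

Compound 4 `CC(=O)c1cc(/C=C/c2ccccc2)cc2cc(-c3ccccc3)[nH]c12` has not yet been measured. It differs from compound 3 in one place: 2-phenylethenyl in place of 4-methoxyphenyl on an aromatic carbon. Within the data shown here, no measured step exchanges a whole group in this way, so the measured steps bear only indirectly. The step of a number 30.3 percentage points lower from compound 1 to compound 3 (beyond the scatter) shows that the methoxy went with a markedly lower number, and compound 4 carries no methoxy; on the other hand the entering group brings a double bond outside aromatic rings, for which no comparison exists. A step upward, back toward compound 1, is therefore expected, though with wide uncertainty; the expected step is a number 18.9 percentage points higher from compound 3 to compound 4 (beyond the scatter). Compound 4 is estimated at 40%, with a range from 20% to 65%.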

Compound 4, a percentage reported as activity, at one concentration (the size of the read-out at that concentration, not a potency): 21.3%
For compound 4 the middle estimate is 18.7 percentage points above the measured one; the measured number falls inside the stated range.
By their numbers in this assay, from the lowest: compounds 3, 4 and 2 (each within the scatter of the next); then compound 1.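

In this assay, the position that carries the phenyl group in compound 1 does not depend on a substituent on that directly attached ring for a lower number: the 2-phenylethenyl group gives a number 30.1 percentage points lower from compound 1 to compound 4 (beyond the scatter). This group has no oxygen and no hydrogen-bond acceptor, yet it matches the 4-methoxyphenyl group, with a number 0.2 percentage points higher from compound 3 to compound 4 (within the scatter), and the 4-fluorophenyl group, with a number 3.5 percentage points lower from compound 2 to compound 4 (within the scatter), so neither a methoxy group nor a fluoro group is needed to reach this level, and a double bond outside aromatic rings fits at this position without loss in this read-out. No measurement at hand explains why three such different groups give numbers this close.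

Every group shown at this position still includes a six-membered aromatic ring, so it remains open whether an amine or a simple longer carbon chain there would hold the number at this level. Going by these compounds, it also remains open whether the double bond itself matters, which the saturated 2-phenylethyl group would test directly.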